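The source may hold more compounds than are shown below. What is called first, only, known or untested is meant among the compounds shown, and "the series" means these compounds.

Compound 1 `COc1cc(C)cc(-c2c(-c3ccnc(-c4ccc(C(C)=O)cc4)c3)cnn2CC#N)c1`: 7020 nM
Compound 2 `COc1cc(C)cc(-c2nn(CC#N)cc2-c2ccc(-c3cccc(C(C)=O)c3)nc2)c1`: 9200 nM
Compound 3 `Cc1cc(O)cc(-c2nn(CC#N)cc2-c2ccnc(-c3ccc(N(C)C)cc3)c2)c1`: 87800 nM

These three values come from a functional assay on COLO 205 cells (Homo sapiens) for inhibition, read by sulforhodamine B assay, with a stated time of 48 h; a higher number here means that more compound is tolerated, a lower number that less compound is tolerated. Compound 1 gives the lowest number of the three. Compound 2 sits close to it, within the usual scatter, so the two cannot be told apart. Compound 3 gives a far higher number, well beyond the scatter; it differs from compound 1 in more than one place, so only its two values can be compared.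

Compound 4 `COc1cc(C)cc(-c2c(-c3ccnc(-c4ccc(N(C)C)cc4)c3)cnn2CC#N)c1` is not yet measured. It differs from compound 1 by dimethylamino in place of acetyl on an aromatic carbon. Going by the values given here, no measured pair mirrors this single change. Among the compounds with values here, the one measured compound carrying a dimethylamino group, compound 3, gives the highest number, though it also carries another difference. On that basis the step is expected to be a 4.3-fold higher number from compound 1 to compound 4 (0.63 log units; beyond the scatter), a rise beyond the scatter. Compound 4 is expected to give 30000 nM, with a range from 8000 nM to 120000 nM.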

Compound 4, concentration lethal to 50% of the cells: > 100000 nM
Compound 4: a limit, no number; the forecaster's own chance of this, stated with the estimate: 10%; middle value at least 3.3-fold (0.52 log units) from the limit.
By their numbers in this assay, from the lowest: compounds 1 and 2 (each within the scatter of the next); then compound 3. At a limit, above all of these: compound 4.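

Going by these compounds alone, changing 4-acetylphenyl to 4-(dimethylamino)phenyl gives the first comparison here that differs in one place, and in this assay it produces an at least 14-fold higher number from compound 1 to compound 4 (1.15 log units; beyond the scatter). This position therefore responds strongly to what it carries, even though both groups have the same heavy-atom count and neither has a ring or a net charge. The result for compound 4 is a limit of the assay, not a number: the limit of > 100000 nM in this assay, at which 1 of the 4 values shown sits.

The compounds shown leave open how a primary amine or a carboxylic acid would behave on this aromatic carbon. They also cannot tell whether removing acetyl or adding dimethylamino matters more.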